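A few compounds are considered here, and "the series" means these few. Any claim that something is new, unique, unknown or untested is made for them only; others in the source may bear on it.

Compound 1, `O=C(Nc1sc2c(c1C(=O)NNc1ccc(Br)cc1)CCCCC2)NS(=O)(=O)c1ccccc1`: in a functional assay on OVCAR-3 cells (Homo sapiens) for inhibition, with a stated time of 48 h (a lower number here means a stronger inhibitor of growth, a higher number a weaker inhibitor of growth), compound 1 gives 14800 nM.
Compound 2, `CCCNC(=O)c1c(NC(=O)NS(=O)(=O)c2ccccc2)sc2c1CCCCC2`: in this assay compound 2 gives > 100000 nM, which is a limit of the assay and not a number.

Compound 2 therefore stands at the weak end of the two values shown, as described in the limit of > 100000 nM in this assay, at which 1 of the 2 values shown sits. Within the data shown here, the single measured step runs from compound 1 to compound 2, an at least 6.7-fold higher number from compound 1 to compound 2 (0.82 log units; beyond the scatter). Compound 3, `O=C(Nc1sc2c(c1C(=O)N1CCN(c3ccccc3)CC1)CCCCC2)NS(=O)(=O)c1ccccc1`, differs from compound 2 by 4-phenylpiperazin-1-yl in place of propylamino on a carbonyl carbon. Among the measured compounds shown here, no measured step covers this exact change; the only related evidence is the step from compound 1 to compound 2, which shows that removing the aryl-bearing group in favour of a propyl chain cost at least a modest amount in this assay. Since compound 3 brings back an aryl-bearing group, though on a different kind of nitrogen, a partial return towards the value of compound 1 is expected, not a full one. Compound 3 is estimated at 30000 nM, with a range from 5000 nM to 150000 nM, which means an expected step of an at least 3.3-fold lower number from compound 2 to compound 3 (0.52 log units; beyond the scatter).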

Compound 3, concentration for 50% growth inhibition: 11900 nM
Compound 3: middle estimate off by 2.5-fold (0.40 log units), on the high side, and the stated range covers the measured number.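

Among these compounds, on the carbonyl carbon, 4-phenylpiperazin-1-yl in place of propylamino gives an at least 8.4-fold lower number from compound 2 to compound 3 (0.92 log units; beyond the scatter) in this assay, so a measurable growth-inhibition value returns with an aryl-bearing group that differs from the one in compound 1. Set against compound 1, 4-phenylpiperazin-1-yl in place of ((4-bromophenyl)amino)amino gives a 1.2-fold lower number from compound 1 to compound 3 (0.09 log units; within the scatter), so these two aryl-bearing groups cannot be told apart in this read-out, even though they reach the carbonyl carbon through different nitrogen arrangements. Compound 2 has a limit and not a number, so the gain over compound 2 can be read only as a lower bound: the limit of > 100000 nM in this assay, at which 1 of the 3 values shown sits.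

The three compounds leave open whether the phenyl ring or the larger count of heavy atoms separates 4-phenylpiperazin-1-yl from propylamino, a question that a piperidin-1-yl or a benzylamino group on the same carbonyl carbon would address. They also leave open whether a methoxy group on the phenyl ring of 4-phenylpiperazin-1-yl would move the value beyond the scatter of compound 3.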